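A few compounds are considered here, and "the series" means these few. Any claim that something is new, unique, unknown or untested is made for them only; others in the source may bear on it.

Compound 1 `Cc1cc(N2CC[C@@H](C)[C@@H](N(C)c3ncnc4[nH]ccc34)C2)n2nc(SCC3CC3)nc2n1` gives 21400 nM in a functional assay on HGC-27 cells (Homo sapiens) for inhibition, read by MTT assay, with a stated time of 72 h; a higher number here means a weaker inhibitor, a lower number a stronger inhibitor. Compound 3 `Cc1ccc(CSc2nc3nc(C)cc(N4CC[C@@H](C)[C@@H](N(C)c5ncnc6[nH]ccc56)C4)n3n2)cc1` gives 15200 nM in this assay, and the two values sit within the usual scatter of each other. Compound 2 `Cc1cc(N2CC[C@@H](C)[C@@H](N(C)c3ncnc4[nH]ccc34)C2)n2nc(SCc3nc4ccccc4[nH]3)nc2n1` reaches only a limit in this assay, > 100000 nM. Compound 4 `Cc1cc(N2CC[C@@H](C)[C@@H](N(C)c3ncnc4[nH]ccc34)C2)n2nc(SCc3ccc([N+](=O)[O-])cc3)nc2n1` differs from compound 1 in one place: 4-nitrophenyl in place of cyclopropyl on a saturated chain carbon bound to a sulfur. Two measured steps alter the same group. Putting 4-methylphenyl in place of cyclopropyl gave a 1.4-fold lower number from compound 1 to compound 3 (0.15 log units; within the scatter), while putting 1H-benzimidazol-2-yl there gave an at least 4.6-fold higher number from compound 1 to compound 2 (0.66 log units; beyond the scatter). The entering 4-nitrophenyl, like 4-methylphenyl, carries one six-membered aromatic ring of carbon only. The expected step is a 1.1-fold lower number from compound 1 to compound 4 (0.03 log units; within the scatter), nothing beyond the scatter. Compound 4 is therefore estimated at 20000 nM in this assay, with a range from 8000 nM to 60000 nM.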

Compound 4, half-maximal inhibitory concentration: 29400 nM
Estimate against measurement, compound 4: 1.5-fold (0.17 log units) below, within the range that was stated.
By their numbers in this assay, from the lowest: compounds 3, 1 and 4 (each within the scatter of the next). At a limit, above all of these: compound 2.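

Putting 4-nitrophenyl in place of cyclopropyl on a saturated chain carbon bound to a sulfur gives a 1.4-fold higher number from compound 1 to compound 4 (0.14 log units; within the scatter), and nitro in place of methyl on an aromatic carbon gives a 1.9-fold higher number from compound 3 to compound 4 (0.29 log units; within the scatter), so cyclopropyl, 4-methylphenyl and 4-nitrophenyl cannot be told apart here. Only 1H-benzimidazol-2-yl stands apart, with an at least 3.4-fold lower number from compound 2 to compound 4 (0.53 log units; beyond the scatter). Compound 2 gives a limit, not a number: the limit of > 100000 nM in this assay, at which 1 of the 4 values shown sits.

From the compounds shown here alone, how an amine or a carboxylic acid would read in place of cyclopropyl stays open, as does a longer chain there.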